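Methoxy on the benzyl group of an enaminone chalcone

The compounds below may be only part of what the source reports. "The series", "measured", "known", "first", "only" and "open" are said of these compounds alone.

Three compounds share a chalcone core. Compound 1 `CN(C)c1ccc(/C=C/C(=O)c2ccc(N(C)C)cc2O)cc1` carries no side chain, compound 2 `CCN(CCCCCCOc1ccc(C(=O)/C=C/c2ccc(N(C)C)cc2)c(O)c1)Cc1ccccc1` bears a six-carbon chain ending in a benzyl(ethyl)amino group, and compound 3 `CCN(CCCCOc1ccc(/C=C/C(=O)c2ccc(N(C)C)cc2O)cc1)Cc1ccccc1N(C)C` a shorter chain ending in a dimethylamino-substituted benzyl. In an assay on isolated protein for inhibition of Amine oxidase [flavin-containing] B (Homo sapiens) (a higher number here means a weaker inhibitor, a lower number a stronger inhibitor), compound 1 gives 12100 nM, compound 2 gives 2100 nM, and compound 3 gives 4300 nM. Compound 2 has the lowest number of the three; compound 3 is nearest and compound 1 furthest, both beyond the scatter. Compound 4 `CCN(CCCCCCOc1ccc(C(=O)/C=C/c2ccc(N(C)C)cc2)c(O)c1)Cc1ccccc1OC` differs from compound 2 by methoxy in place of hydrogen on an aromatic carbon. Among the compounds with values here, no comparable step is known here. The step from compound 2 to compound 4 is expected to be small, a 1.2-fold higher number from compound 2 to compound 4 (0.08 log units; within the scatter), with no change beyond the scatter. Compound 4 is therefore estimated at 2500 nM, within 900 nM to 7000 nM.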

Compound 4, half-maximal inhibitory concentration: 700 nM
Beside the measured number, compound 4's estimate is 3.6-fold (0.55 log units) above it; the whole stated range lies above it.
By their numbers in this assay, from the lowest: compound 4; then compound 2; then compound 3; then compound 1.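

Changing benzyl to 2-methoxybenzyl in the benzyl(ethyl)amino group gives a 3.0-fold lower number from compound 2 to compound 4 (0.48 log units; beyond the scatter) in this assay, a modest step beyond the scatter. Within the data shown here, this is the first single-place comparison in the set, and it shows that this aromatic carbon, ortho to a large group, is not indifferent to substitution. No measurement shown here accounts for the step.

Going by these compounds, whether a hydroxyl, an ethoxy or a fluorine on this carbon would give a similar number remains open. So does whether methoxy would have the same effect on the shorter chain of compound 3.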